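An Amino Group Added to the Ethyl Chain

The compounds below may be only part of what the source reports. "The series", "measured", "known", "first", "only" and "open" are said of these compounds alone.

Compound 1 `Cn1cnc2c(NC(=N)N)nc(N)nc21` gives in a functional assay on MCF7 cells (Homo sapiens) for inhibition, read by fluorescence, with a stated time of 72 h (on this read-out higher numbers stand for weaker inhibition and lower numbers for stronger inhibition), only a limit of the assay, > 100000 nM. Going by the values given here, compound 2 `CCn1cnc2c(NC(=N)N)nc(N)nc21` gives in this assay 54300 nM, the only true number among the two values available. The step between them is an at least 1.8-fold lower number from compound 1 to compound 2 (0.26 log units; that floor lies within the scatter). Compound 3 `N=C(N)Nc1nc(N)nc2c1ncn2CCN` differs from compound 2 by amino in place of hydrogen on a saturated chain carbon, two bonds along the chain from an aromatic nitrogen. Among the compounds with values here, no measured step touches this kind of change; the single measured step concerns a different place and itself sits within the scatter. Compound 3 is therefore expected to show a 1.1-fold lower number from compound 2 to compound 3 (0.04 log units; within the scatter), nothing beyond the scatter. For compound 3 the estimate in this assay is 50000 nM, ranging from 15000 nM to 150000 nM.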

Compound 3, half-maximal inhibitory concentration: > 100000 nM
Compound 3 was reported as a limit; the forecaster's own chance of this, stated with the estimate: 30%; at least 2.0-fold (0.30 log units) between middle value and limit.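

Going by these compounds alone, this is the first reading of a change at this place on the ethyl chain, and amino there gives an at least 1.8-fold higher number from compound 2 to compound 3 (0.26 log units; that floor lies within the scatter), so no gain appears, though no real loss can be claimed either. Compound 3 sits at a limit of the assay, not at a number: the limit of > 100000 nM in this assay, at which 2 of the 3 values shown sit. The step from compound 1 to compound 3 cannot be read, as both values are limits.

What number lies behind the limit of compound 3 stays open. So does whether a hydroxyl group, a carboxylic acid or a longer chain at this place would read any differently.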